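Tetrazolyl in Place of Dichlorophenyl: an Expected Weakening

This account rests on a few compounds, and the source may have more. Where it says the series, first, only, none or still open, it means among the compounds named here.

Three compounds share a core. Compound 1 `N#Cc1cc(Cl)c2nc(O)c(-c3ccccc3)c(O)c2c1` gives in an assay on isolated protein for inhibition of fatty acid synthase (Rattus norvegicus); a lower number here means a stronger inhibitor, a higher number a weaker inhibitor "not determined" (no result reported). Compound 2 `O=C(O)c1ccc2nc(O)c(-c3ccccc3)c(O)c2c1` gives in this assay only a limit, > 15000 nM. Going by the values given here, compound 3 `O=[N+]([O-])c1cc2c(O)c(-c3ccc(Cl)cc3Cl)c(O)nc2cc1Cl` gives 443 nM in this assay, the only number among the three, so it stands alone as the reference for what follows. Compound 2 and compound 3 differ in more than one place, so their two values show no more than that one sits at a limit of > 15000 nM in this assay, at which 1 of the 3 values shown sits, and the other gives a number.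

Compound 4 `O=[N+]([O-])c1cc2c(O)c(-c3nn[nH]n3)c(O)nc2cc1Cl` differs from compound 3 in one place, 2H-tetrazol-5-yl in place of 2,4-dichlorophenyl on an aromatic carbon. Among the compounds with values here, no step between measured compounds is available for this change, so the expectation rests on the size of the exchange alone. The author expects a step beyond the scatter toward weaker inhibition, an 11-fold higher number from compound 3 to compound 4 (1.05 log units; beyond the scatter), and allows that the assay may report only a limit. For compound 4 the estimate in this assay is 5000 nM, within 1000 nM to 30000 nM.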

Compound 4, half-maximal inhibitory concentration: 2600 nM
Estimate against measurement, compound 4: 1.9-fold (0.28 log units) above; the range from low to high includes it.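

In this assay, going by these compounds alone, 2H-tetrazol-5-yl in place of 2,4-dichlorophenyl gives a 5.9-fold higher number from compound 3 to compound 4 (0.77 log units; beyond the scatter), the first step that can be read at this position, on an aromatic carbon ortho to two hydroxy groups. The change weakens inhibition, yet compound 4 still gives a number, so this position can carry a five-membered aromatic ring with 4 hetero atoms in place of a six-membered ring of carbon only without the value reaching a limit. Compound 2, which differs from compound 3 in more than one place, is the only compound with a limit of the assay: the limit of > 15000 nM in this assay, at which 1 of the 4 values shown sits.

The compounds shown leave open whether the weakening follows the loss of the two chlorine atoms or the arrival of the tetrazole ring. Neither is separated here, and a 4-chlorophenyl or a carboxylic acid at this position on the same core would bear on that question.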